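The source may hold more compounds than are shown below. What is called first, only, known or untested is meant among the compounds shown, and "the series" means these compounds.

Measured so far:
compound 1 `Cc1cn2c(/C=N/NC(=N)N)c(-c3ccncc3)nc2s1` — 19500 nM
compound 2 `Cc1cn2c(/C=N/NC(=N)N)c(-c3cccnc3)nc2s1` — 10200 nM
compound 3 `N=C(N)N/N=C/c1c(-c2cccnc2)nc2sc(Cl)cn12` — 18200 nM

In a functional assay (Homo sapiens) for antiproliferative activity (on this read-out lower numbers stand for stronger inhibition of growth and higher numbers for weaker inhibition of growth), the three numbers lie close together. The change from compound 2 to compound 1 is pyridin-4-yl in place of pyridin-3-yl on an aromatic carbon and gives the step of a 1.9-fold higher number from compound 2 to compound 1 (0.28 log units; within the scatter). The step of a 1.8-fold higher number from compound 2 to compound 3 (0.25 log units; within the scatter) is likewise small. Compound 3 stands nearest to compound 1 and furthest from compound 2, both gaps within the scatter, so no order among the three is claimed.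

Compound 4 `N=C(N)N/N=C/c1c(-c2ccncc2)nc2sc(Cl)cn12` has not been measured. It differs from compound 3 by pyridin-4-yl in place of pyridin-3-yl on an aromatic carbon, the place being described in the same words as for the pair compound 2 and compound 1, so this is the same change. The core shared by compound 3 and compound 4 differs from that of compound 1 and compound 2 by chloro in place of methyl on an aromatic carbon.

For compound 4 in this assay a step of a 1.6-fold higher number from compound 3 to compound 4 (0.22 log units; within the scatter) is expected, resting on the step of a 1.9-fold higher number from compound 2 to compound 1 (0.28 log units; within the scatter) seen for the same change, itself within the scatter. Compound 4 is accordingly estimated at 30000 nM, with a range from 12000 nM to 75000 nM.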

Compound 4, concentration for 50% growth inhibition: 5890 nM
For compound 4 the middle estimate is 5.1-fold (0.71 log units) above the measured one; the measured number lies below the stated range.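

In this assay, pyridin-4-yl in place of pyridin-3-yl on the chloro-bearing core gives a 3.1-fold lower number from compound 3 to compound 4 (0.49 log units; beyond the scatter), and this step does not match the one for the same change on the methyl-bearing core: the same change on two cores in this assay, a 1.9-fold higher number (0.28 log units; within the scatter) from compound 2 to compound 1 and a 3.1-fold lower number (0.49 log units; beyond the scatter) from compound 3 to compound 4, 5.9-fold (0.77 log units) apart, beyond the scatter of two such steps
Read from the other place, chloro in place of methyl with pyridin-4-yl present gives a 3.3-fold lower number from compound 1 to compound 4 (0.52 log units; beyond the scatter), and this too differs from the step seen with pyridin-3-yl present: the same change on two cores in this assay, a 1.8-fold higher number (0.25 log units; within the scatter) from compound 2 to compound 3 and a 3.3-fold lower number (0.52 log units; beyond the scatter) from compound 1 to compound 4, 5.9-fold (0.77 log units) apart, beyond the scatter of two such steps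
In these four compounds, then, neither change carries over unaltered from one core to the other, so a step measured on one core is a poor guide to the other; this rests on a single closed set of four compounds and does not show why the steps differ or how the changes would behave on any further core.

Open, from the compounds shown here alone, is whether the same dependence appears with other groups on that aromatic carbon in place of methyl and chloro, such as bromo, an amine or a longer alkyl chain. Also open, going by these compounds, is whether it persists when a phenyl ring stands in place of the pyridine ring.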